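Ethynyl in place of thiophen-3-yl: working notes

The source may report more compounds than this note shows. Statements on the series, on what has been measured and on what is new or still open speak of the compounds shown alone.

- compound 1 `CSc1ncnc2c1c(-c1cccs1)cn2[C@@H]1O[C@H](CO)[C@@H](O)[C@H]1O`: 1130 nM
- compound 2 `CSc1ncnc2c1c(-c1ccsc1)cn2[C@@H]1O[C@H](CO)[C@@H](O)[C@H]1O`: 4590 nM
- compound 3 `C#Cc1cn([C@@H]2O[C@H](CO)[C@@H](O)[C@H]2O)c2ncnc(SC)c12`: not yet measured

In a functional assay on HL-60 cells (Homo sapiens) for antiproliferative activity, read by XTT assay, with a stated time of 72 h (on this read-out higher numbers stand for weaker inhibition and lower numbers for stronger inhibition), compound 2, at 4590 nM, holds the higher of the two numbers. The next change gives compound 3, with ethynyl in place of thiophen-3-yl on an aromatic carbon.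

Going by the values given here, only one measured step bears on this: a 4.1-fold higher number from compound 1 to compound 2 (0.61 log units; beyond the scatter). That modest step keeps a thiophene ring on the same carbon, so the data do not show what happens when the ring is removed. With compound 2 at the high end at 4590 nM, a modest step towards a lower number is expected, though with wide uncertainty. The estimated move is a 3.1-fold lower number from compound 2 to compound 3 (0.49 log units; beyond the scatter). For compound 3 the expected value is 1500 nM, within an estimated range of 200 nM to 10000 nM.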

Compound 3, half-maximal inhibitory concentration: 50 nM
Estimate against measurement, compound 3: 30-fold (1.48 log units) above, and the stated range ends above it.
By their numbers in this assay, from the lowest: compound 3; then compound 1; then compound 2.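

In this assay, taking the thiophene ring off this aromatic carbon and putting ethynyl there gives a 92-fold lower number from compound 2 to compound 3 (1.96 log units; beyond the scatter), and the same change from the other thiophene gives a 23-fold lower number from compound 1 to compound 3 (1.35 log units; beyond the scatter). Both steps are large, whereas moving the point of attachment of the thiophene gave only a 4.1-fold higher number from compound 1 to compound 2 (0.61 log units; beyond the scatter), so this position responds far more to the replacement of the ring by ethynyl than to the thiophene isomer it carries. No available evidence accounts for this gain in potency.

On these data alone, whether the gain comes from the triple bond or simply from the absence of a ring stays open, and an ethyl or ethenyl group on the same carbon would separate the two. Also open, as far as these compounds go, is whether ethynyl keeps this advantage on a core with an amine in place of the methylsulfanyl group.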